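Replacing ethyl with an aryl group on the fused core

This account rests on a few compounds, and the source may have more. Where it says the series, first, only, none or still open, it means among the compounds named here.

Compound 1 `CCc1nc2sccn2c1/C=N/OCc1ccc(Cl)c(Cl)c1`: 2600 nM
Compound 2 `C(=N/OCc1ccccc1)\c1c(-c2ccc3ccccc3c2)nc2occn12`: 840 nM
Compound 3 `FC(F)(F)c1ccc(CO/N=C/c2c(-c3ccc4ccccc4c3)nc3occn23)cc1`: 470 nM

In an assay on HepG2 cells for agonist activity at nuclear receptor subfamily 1 group I member 3 (Homo sapiens), read by a luciferase reporter, with a stated time of 23 h (on this read-out lower numbers stand for an effect already at smaller amounts and higher numbers for an effect only at larger amounts of compound), compound 1 gives the highest of the three numbers; compound 2 sits at 840 nM and compound 3 at 470 nM, both beyond the scatter from compound 1. Compound 4 `CC(C)c1ccc(-c2nc3sccn3c2/C=N/OCc2ccc(Cl)c(Cl)c2)cc1` differs from compound 1 by 4-isopropylphenyl in place of ethyl on an aromatic carbon. Among the compounds with values here, no measured step mirrors this change; the only measured step, a 1.8-fold lower number from compound 2 to compound 3 (0.25 log units; within the scatter), concerns the benzyl side and does not bear on it. Compounds 2 and 3, which carry an aryl group at the corresponding place, differ from compound 1 in several places at once, so they only hint at a lower number. Compound 4 is therefore expected at 800 nM (range 250 nM to 2600 nM), a step of a 3.3-fold lower number from compound 1 to compound 4 (0.51 log units; beyond the scatter).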

Compound 4, half-maximal effective concentration: 590 nM
Compound 4: middle estimate off by 1.4-fold (0.13 log units), on the high side, within the range that was stated.
By their numbers in this assay, from the lowest: compounds 3, 4 and 2 (each within the scatter of the next); then compound 1.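

In this assay, 4-isopropylphenyl in place of ethyl on this aromatic carbon gives a 4.4-fold lower number from compound 1 to compound 4 (0.64 log units; beyond the scatter), with the rest of the molecule unchanged. This single-place comparison shows that the number falls beyond the scatter at this position, which compounds 2 and 3, differing from compound 1 in several places, could only hint at. No measurement at hand gives a reason for this step. Going by these compounds, what a plain phenyl, a longer chain or a phenyl bearing a carboxylic acid would give at this place stays open, as does the part the isopropyl plays in the step.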